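Series notes: from compound 1 to compound 4

The compounds below may be only part of what the source reports. "The series", "measured", "known", "first", "only" and "open" are said of these compounds alone.

Compound 1 `CC(C)c1ccc(-c2nc(SCc3cn(CC(=O)NC(=O)Nc4ccccn4)nn3)nc(Nc3cccc(C(F)(F)F)c3)c2C#N)cc1` in a functional assay on MGC-803 cells (Homo sapiens) for inhibition, read by MTT assay, with a stated time of 72 h (a higher number here means a weaker inhibitor, a lower number a stronger inhibitor), gives > 64000 nM, which is a limit of the assay. Compound 2 `CC(C)c1ccc(-c2nc(SCc3cn(CC(=O)NC(=O)Nc4ccccn4)nn3)nc(Nc3cccc([N+](=O)[O-])c3)c2C#N)cc1` gives > 64000 nM, likewise a limit. Compound 3 `CC(C)c1ccc(-c2nc(SCc3cn(CC(=O)NC(=O)Nc4ccccn4)nn3)nc(Nc3ccccc3F)c2C#N)cc1` gives > 64000 nM, also a limit.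

Compound 1 thus stands at the same limit as the other two (the limit of > 64000 nM in this assay, at which 3 of the 3 values shown sit); no number places it relative to either of them. The steps a step that the two limits leave unreadable from compound 1 to compound 2 and a step that the two limits leave unreadable from compound 1 to compound 3 are unreadable, as is a step that the two limits leave unreadable from compound 2 to compound 3. Compound 4 `Cc1ccccc1Nc1nc(SCc2cn(CC(=O)NC(=O)Nc3ccccn3)nn2)nc(-c2ccc(C(C)C)cc2)c1C#N` differs from compound 1 by 2-methylphenyl in place of 3-(trifluoromethyl)phenyl on a nitrogen on an aromatic ring. Among the measured compounds shown here, the only measured step of the same kind, a change of the group on a nitrogen on an aromatic ring, is a step that the two limits leave unreadable from compound 1 to compound 3, which gives no size in either direction. The expectation is therefore no readable step, a number no higher from compound 1 to compound 4 (the limit leaves the size open). Compound 4 is estimated at 64000 nM in this assay, most likely again only a limit, within 20000 nM to 200000 nM.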

Compound 4, half-maximal inhibitory concentration: 19000 nM
The estimate for compound 4 lay 3.4-fold (0.53 log units) above the measured number; measured number below the stated range.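

The group on a nitrogen on an aromatic ring can move the read-out in this assay: 2-methylphenyl gives the only number shown, with an at least 3.3-fold lower number from compound 1 to compound 4 (0.52 log units; beyond the scatter) for its replacement of 3-(trifluoromethyl)phenyl and an at least 3.3-fold lower number from compound 2 to compound 4 (0.52 log units; beyond the scatter) for its replacement of 3-nitrophenyl. Methyl in place of fluoro on an aromatic carbon alone gives an at least 3.3-fold lower number from compound 3 to compound 4 (0.52 log units; beyond the scatter). The true sizes of these steps stay open because the other values are only limits: the limit of > 64000 nM in this assay, at which 3 of the 4 values shown sit.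

Going by these compounds, whether an ethyl, a methoxy or an amine in place of this methyl would give a lower or higher number remains open. So does the number for plain phenyl on the same nitrogen.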